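Ethyl to Butyl: The Step After Compound 2

The compounds below may be only part of what the source reports. "The series", "measured", "known", "first", "only" and "open" are said of these compounds alone.

Going by the values given here, compound 1 `O=C1OC[C@H](Cc2ccccc2)[C@H]1Cc1ccc(Cl)c(Cl)c1` gives 19000 nM in a functional assay on HL-60 cells (Homo sapiens) for cytotoxicity, read by WST assay, with a stated time of 48 h (a higher number here means that more compound is needed for the effect, a lower number that less compound is needed), and compound 2 `CCc1ccc(C[C@H]2COC(=O)[C@@H]2Cc2ccc(Cl)c(Cl)c2)cc1` gives 16000 nM on the same read-out, so compound 2 stands within the scatter of the only other measured compound. Compound 3 `CCCCc1ccc(C[C@H]2COC(=O)[C@@H]2Cc2ccc(Cl)c(Cl)c2)cc1` follows from compound 2 by ethyl in place of hydrogen on a saturated chain carbon, two bonds along the chain from an aromatic carbon with ethyl in place of hydrogen on a saturated chain carbon, two bonds along the chain from an aromatic carbon, so that ethyl becomes butyl. Among the compounds with values here, only one measured step bears on this change: a 1.2-fold lower number from compound 1 to compound 2 (0.07 log units; within the scatter) for ethyl in place of hydrogen on an aromatic carbon, and it lies within the scatter. Going by that single small step, the change expected in this assay also stays within the scatter, with a slight lean towards a lower number. The estimate is a 1.3-fold lower number from compound 2 to compound 3 (0.12 log units; within the scatter) as the expected step. Compound 3 is estimated at 12000 nM with an expected range from 5000 nM to 28000 nM in this measurement.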

Compound 3, half-maximal effective concentration: 9400 nM
For compound 3 the middle estimate is 1.3-fold (0.11 log units) above the measured one, and the stated range covers the measured number.
By their numbers in this assay, from the lowest: compounds 3, 2 and 1 (each within the scatter of the next, the first and the last beyond it).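

Taken alone, the change from ethyl to butyl gives a 1.7-fold lower number from compound 2 to compound 3 (0.23 log units; within the scatter), so lengthening the chain at this saturated carbon, two bonds along the chain from an aromatic carbon, cannot be told apart from the scatter of this assay. Measured against the compound with hydrogen on the aromatic carbon, however, butyl gives a 2.0-fold lower number from compound 1 to compound 3 (0.31 log units; beyond the scatter), the first step shown here that passes the scatter, and only modestly. Only the two ends of the set, hydrogen and butyl, are therefore distinguishable, while ethyl cannot be separated from either. Nothing at hand accounts for this difference.

As far as these compounds go, whether a longer chain than butyl would extend this modest difference remains open. So does the effect of an amine or a carboxylic acid placed on the chain.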